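Fluorinated phenyl rings on the shared core against HT-29 cells

The source may report more compounds than this note shows. Statements on the series, on what has been measured and on what is new or still open speak of the compounds shown alone.

Measured compounds:
compound 1 `COc1cc2c(Oc3ccc(NC(=O)c4nn(-c5ccccc5OC(F)(F)F)c(=O)cc4C)cc3F)ccnc2cc1OCCCN1CCN(C)CC1`, 180 nM
compound 2 `COc1cc2c(Oc3ccc(NC(=O)c4nn(-c5cccc(F)c5)c(=O)cc4C)cc3F)ccnc2cc1OCCCN1CCN(C)CC1`, 250 nM
compound 3 `COc1ccc(-n2nc(C(=O)Nc3ccc(Oc4ccnc5cc(OCCCN6CCN(C)CC6)c(OC)cc45)c(F)c3)c(C)cc2=O)cc1`, 3520 nM

All three share one core and differ only in the aryl group attached to an aromatic nitrogen. In a functional assay on HT-29 cells (Homo sapiens) for inhibition, read by MTT assay, with a stated time of 72 h (on this read-out lower numbers stand for stronger inhibition and higher numbers for weaker inhibition), compound 1 gives 180 nM and compound 2 gives 250 nM; the step of a 1.4-fold higher number from compound 1 to compound 2 (0.14 log units; within the scatter) lies within the scatter. Compound 3, with 4-methoxyphenyl on that nitrogen, gives 3520 nM and stands highest of the three, far weaker than either neighbour: a 20-fold higher number from compound 1 to compound 3 (1.29 log units; beyond the scatter) and a 14-fold higher number from compound 2 to compound 3 (1.15 log units; beyond the scatter).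

Compound 4 `COc1cc2c(Oc3ccc(NC(=O)c4nn(-c5ccc(F)c(F)c5)c(=O)cc4C)cc3F)ccnc2cc1OCCCN1CCN(C)CC1` is not yet measured. It differs from compound 3 by 3,4-difluorophenyl in place of 4-methoxyphenyl on an aromatic nitrogen. The step from compound 2 to compound 3 bears most directly on this change, since it exchanged a fluorinated phenyl for the 4-methoxyphenyl and gave a 14-fold higher number from compound 2 to compound 3 (1.15 log units; beyond the scatter); compound 4 carries two fluorines on the ring, reversing that exchange with one fluorine added. Compound 4 is therefore expected to return to the level of compound 2 and compound 1, a large step downward of roughly a 14-fold lower number from compound 3 to compound 4 (1.15 log units; beyond the scatter) in this assay. Compound 4 is estimated at 250 nM, within a range of 100 nM to 700 nM.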

Compound 4, half-maximal inhibitory concentration: 170 nM
Compound 4: the middle estimate sits 1.5-fold (0.17 log units) above what was measured; the range from low to high includes it.
By their numbers in this assay, from the lowest: compounds 4, 1 and 2 (each within the scatter of the next); then compound 3.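

In this assay, 3,4-difluorophenyl in place of 4-methoxyphenyl on the aromatic nitrogen gives a 21-fold lower number from compound 3 to compound 4 (1.32 log units; beyond the scatter) and so reproduces the large gap around compound 3 with a third aryl group, one with the same number of heavy atoms as the group it replaces. A second fluorine on the ring of compound 2 stays within the scatter, at a 1.5-fold lower number from compound 2 to compound 4 (0.17 log units; within the scatter) in the same assay, so this added fluoro on an aromatic carbon shows no readable effect here. Exchanging 2-(trifluoromethoxy)phenyl for 3,4-difluorophenyl also stays within the scatter, at a 1.1-fold lower number from compound 1 to compound 4 (0.02 log units; within the scatter) on this read-out, so compounds 1, 2 and 4 now form one level with three different fluorine-bearing aryl groups, from which only compound 3 stands apart.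

The compounds shown leave open whether an unsubstituted phenyl, or an aryl ring bearing an amine or a carboxylic acid, would sit at the level of compounds 1, 2 and 4 or at that of compound 3. Nothing presented here explains why compound 3 differs from the other three.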